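Acetyl Variants on a Shared Core: Working Notes

The source may hold more compounds than are shown below. What is called first, only, known or untested is meant among the compounds shown, and "the series" means these compounds.

Measured so far:
- compound 1 `C=C1C(=O)O[C@]2(C)CC[C@@H]1C[C@H](O)[C@@]1(C)CC[C@H](O1)[C@](C)(O)CC[C@H]2OC(C)=O`: in a functional assay on HEp-2 cells (Homo sapiens) for cytotoxicity, read by MTT assay (on this read-out higher numbers stand for an effect only at larger amounts of compound and lower numbers for an effect already at smaller amounts), compound 1 gives < 20 ug/mL, which is a limit of the assay.
- compound 2 `C=C1C(=O)O[C@]2(C)CC[C@@H]1C[C@H](OC(C)=O)[C@@]1(C)CC[C@H](O1)[C@](C)(O)CC[C@H]2OC(C)=O`: in this assay compound 2 gives < 20 ug/mL, again a limit.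
- compound 3 `C=C1C(=O)O[C@]2(C)CC[C@@H]1C[C@H](O)[C@@]1(C)CC[C@H](O1)[C@](C)(O)CCC2=O`: in this assay compound 3 gives < 20 ug/mL, also a limit.

Compound 1 and compound 2 differ in one place: acetyl in place of hydrogen on an oxygen on a saturated carbon. The step that the two limits leave unreadable from compound 1 to compound 2 cannot be sized, as both ends are limits. The cores of compound 1 and compound 3 differ in more than one place, and that difference is not broken down here.

Compound 4 `C=C1C(=O)O[C@]2(C)CC[C@@H]1C[C@H](OC(C)=O)[C@@]1(C)CC[C@H](O1)[C@](C)(O)CCC2=O` is not yet measured. It stands to compound 3 as compound 2 stands to compound 1, by the same change at the same place: acetyl in place of hydrogen on an oxygen on a saturated carbon.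

The whole set sits at the limit of < 20 ug/mL in this assay, at which 3 of the 3 values shown sit, so no effect of the acetyl on this read-out has yet been resolved. Compound 4 is expected to give 10 ug/mL in this assay, most likely again as a limit. This rests on compound 3 giving < 20 ug/mL and on the unreadable a step that the two limits leave unreadable from compound 1 to compound 2. The expected step is a step that the limit leaves unreadable from compound 3 to compound 4, with a range from 2 ug/mL to 20 ug/mL.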

Compound 4, concentration for half-maximal effect: < 20 ug/mL
Compound 4: a limit, no number; the forecaster's own chance of this, stated with the estimate: 80%; the middle value is on the limit's open side.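

No new step can be read: compound 3 and compound 4 both give only a limit in this assay, so the hydroxy to acetoxy change between them cannot be sized: the limit of < 20 ug/mL in this assay, at which 4 of the 4 values shown sit.

The compounds shown leave open where each of the four actually lies beyond that limit, and whether the acetyl changes this read-out at all.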